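Series notes: phenyl-acid ethers in liver microsomes

The source may report more compounds than this note shows. Statements on the series, on what has been measured and on what is new or still open speak of the compounds shown alone.

Measured so far:
compound 1 `O=C(O)c1cc(-c2cccc(COc3ccc4c(c3)CN(C3CCCC3)C4=O)c2)ccc1O` gives 9%;
compound 2 `Cn1sc2cc(OCc3cccc(-c4ccc(Cl)c(C(=O)O)c4)c3)ccc2c1=O` gives 84%;
compound 3 `CC(C)Cn1sc2cc(OCc3cccc(-c4ccc(Cl)c(C(=O)O)c4)c3)ccc2c1=O` gives 86%.

All three numbers come from an ADME assay on microsomes from liver (Rattus norvegicus) for metabolic stability, read by LC-MS, with a stated time of 1 h, at 37 degrees C, tested at 4 uM; a lower number here means that less of the compound is left, a higher number that more of the compound is left. Compound 1 stands lowest of the three; the nearest, compound 2, sits well beyond the scatter above it, and compound 3 further still. Among the compounds with values here, the only step with a single change, a number 2 percentage points higher from compound 2 to compound 3 (within the scatter), lies within the scatter and concerns the substituent on the aromatic nitrogen of the core shared by compound 2 and compound 3, a core that compound 1 does not have.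

Compound 4 `COc1ccc(C(=O)O)cc1-c1cccc(COc2ccc3c(c2)CN(C2CCCC2)C3=O)c1` is not yet measured. It differs from compound 1 at one place: 5-carboxy-2-methoxyphenyl in place of 3-carboxy-4-hydroxyphenyl on an aromatic carbon. Within the data shown here, no measured step touches a 3-carboxy-4-hydroxyphenyl or a 5-carboxy-2-methoxyphenyl group, and no measured pair shares the core of compound 1 with compound 4. The only direct anchor is the value of compound 1 in this assay, and the gap to compound 2 and compound 3 cannot be read as a step, since several parts of the molecule differ at once.

Among the measured compounds shown here, with no bearing step, the expected change a number 16 percentage points higher from compound 1 to compound 4 (beyond the scatter) is a guess with a wide range. Compound 4 is estimated at 25%, between 5% and 60%.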

Compound 4, percent of the compound remaining: 30%
Compound 4: the middle estimate sits 5 percentage points below what was measured, within the range that was stated.
By their numbers in this assay, from the lowest: compound 1; then compound 4; then compounds 2 and 3 (each within the scatter of the next).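

On the core of compound 1, 5-carboxy-2-methoxyphenyl in place of 3-carboxy-4-hydroxyphenyl on an aromatic carbon gives a number 21 percentage points higher from compound 1 to compound 4 (beyond the scatter) in this assay. Within the data shown here, this is the first step at this place, and it shows that the number in this assay responds to the aryl group here while the rest of the molecule stays the same, whereas the one earlier step, on the substituent at the aromatic nitrogen of a different core, stayed within the scatter. Nothing at hand bears on the origin of this rise.

Among these compounds, the single step exchanges the hydroxy group for a methoxy group and also changes where the carboxylic acid sits, so the share of each change stays open, and a plain carboxyphenyl group or an ethoxy group in place of the methoxy group on the same core would help to separate them. Going by these compounds, whether the same exchange carries over to the core shared by compound 2 and compound 3 also remains open.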